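This account rests on a few compounds, and the source may have more. Where it says the series, first, only, none or still open, it means among the compounds named here.

The measured compounds, with their readings in an ADME assay on MT4 cells (Homo sapiens) for cytotoxicity, read by MTT assay, with a stated time of 5 days; a lower number here means that less compound is tolerated, a higher number that more compound is tolerated:

compound 1 `COc1cc2cc(C#N)ccc2c(OC)c1Oc1cc(NC(C)C)nc(Nc2ccc(C#N)cc2)n1`: > 125000 nM (a limit of the assay, not a number)
compound 2 `COc1cc2cc(C#N)ccc2c(OC)c1Oc1cc(NC(C)(C)C)nc(Nc2ccc(C#N)cc2)n1`: > 125000 nM (also a limit)
compound 3 `COc1cc2cc(C#N)ccc2c(OC)c1Oc1cc(NCCCO)nc(Nc2ccc(C#N)cc2)n1`: 23500 nM

Compound 1 stands at the limit of > 125000 nM in this assay, at which 2 of the 3 values shown sit; for it only this limit is known, and it is one of two such limits among the three readings. Compound 4 `COc1cc2cc(C#N)ccc2c(OC)c1Oc1cc(NCC(O)CO)nc(Nc2ccc(C#N)cc2)n1` has not yet been measured. It differs from compound 1 in one place: 2,3-dihydroxypropyl in place of isopropyl on a nitrogen on an aromatic ring.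

Within the data shown here, two measured steps bear on this change. The step of an at least 5.3-fold lower number from compound 1 to compound 3 (0.72 log units; beyond the scatter) replaces the same isopropyl with a chain carrying one hydroxyl, and the step of an at least 5.3-fold lower number from compound 2 to compound 3 (0.72 log units; beyond the scatter) reads the same way from the tert-butyl compound. The step that the two limits leave unreadable from compound 1 to compound 2 sits between two limits and cannot be read. The change into compound 4 brings a chain with two hydroxyls rather than one, so a step of at least the same kind is expected, in the direction of a lower number: an at least 5.0-fold lower number from compound 1 to compound 4 (0.69 log units; beyond the scatter).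

Compound 4 is therefore estimated to give 25000 nM in this assay, with the expected range running from 7000 nM to 125000 nM.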

Compound 4, half-maximal cytotoxic concentration: 29500 nM
The estimate for compound 4 lay 1.2-fold (0.07 log units) below the measured number; the measured number falls inside the stated range.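

On this nitrogen, a second hydroxyl on the chain makes no readable difference in this assay: the step is a 1.3-fold higher number from compound 3 to compound 4 (0.10 log units; within the scatter). The lower number seen with a single hydroxyl therefore also holds for the 2,3-dihydroxypropyl chain, which gives an at least 4.2-fold lower number from compound 1 to compound 4 (0.62 log units; beyond the scatter) and an at least 4.2-fold lower number from compound 2 to compound 4 (0.62 log units; beyond the scatter). Both of these steps start from a limit of the assay rather than a number, so each gives only the smallest size the step can have: the limit of > 125000 nM in this assay, at which 2 of the 4 values shown sit.

Among the four compounds, the two with a hydroxyl on the chain give readings and the two with plain isopropyl or tert-butyl groups stay at the limit, but these compounds cannot show whether the hydroxyl itself matters or whether another oxygen or nitrogen group, such as a methyl ether, an amine or a carboxylic acid, would read the same way. From the compounds shown here alone, it also remains open how a shorter or longer hydroxyl-bearing chain would read in this assay.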